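Trifluoromethyl for Trifluoromethoxy: Expecting the Next Cytotoxicity Value

The source may hold more compounds than are shown below. What is called first, only, known or untested is meant among the compounds shown, and "the series" means these compounds.

Of the compounds shown here, three have been measured in a functional assay on HL-60 cells (Homo sapiens) for cytotoxicity, read by luminescence and CellTiter-Glo, with a stated time of 3 days; on this read-out lower numbers stand for stronger inhibition and higher numbers for weaker inhibition. Compound 1 `O=C(Nc1ccc(OC(F)(F)F)cc1)c1cc(F)ccc1O` gives 850 nM, and compound 2 `O=C(Nc1ccc(C(F)(F)F)cc1)c1cc(F)ccc1O` gives 490 nM. These two differ in one place, (trifluoromethyl in place of trifluoromethoxy on an aromatic carbon), and the step was a 1.7-fold lower number from compound 1 to compound 2 (0.24 log units; within the scatter). Compound 3 `O=C(Nc1ccc(OC(F)(F)F)c(Cl)c1)c1cc(Cl)ccc1O` gives 450 nM in this assay; the difference between the core of compound 1 and the core of compound 3 is not broken down here.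

Compound 4 `O=C(Nc1ccc(C(F)(F)F)c(Cl)c1)c1cc(Cl)ccc1O` has not yet been measured. It differs from compound 3 by trifluoromethyl in place of trifluoromethoxy on an aromatic carbon. Going by the values given here, this is the same kind of change as the one from compound 1 to compound 2, though here the place is also ortho to a chloro group, which the earlier pair lacks. Among the compounds with values here, only one earlier example of this change exists, so the expectation rests on compound 3 at 450 nM and on the modest earlier step of a 1.7-fold lower number from compound 1 to compound 2 (0.24 log units; within the scatter). The step expected from this change is a 1.5-fold lower number from compound 3 to compound 4 (0.18 log units; within the scatter). Compound 4 is therefore estimated at 300 nM in this assay, with an expected range from 150 nM to 700 nM.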

Compound 4, half-maximal inhibitory concentration: 460 nM
The estimate for compound 4 lay 1.5-fold (0.19 log units) below the measured number, within the range that was stated.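

In this assay, putting trifluoromethyl in place of trifluoromethoxy on the core of compound 3 gave a 1.0-fold higher number from compound 3 to compound 4 (0.01 log units; within the scatter), so on this core the swap has no effect that can be told apart from the ordinary spread of repeated measurements. Set beside the earlier case, the two steps agree as closely as such measurements allow: the same change on two cores in this assay, a 1.7-fold lower number (0.24 log units; within the scatter) from compound 1 to compound 2 and a 1.0-fold higher number (0.01 log units; within the scatter) from compound 3 to compound 4, 1.8-fold (0.25 log units) apart, within the scatter of two such steps. This shows that, across these two cores, the swap gives no sign of behaving differently, but since both steps lie within the scatter, it does not show that the swap has a real effect on either core, and two pairs cannot speak for other cores in the series.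

The compounds shown carry only trifluoromethoxy or trifluoromethyl at this place, so it remains open what an amine, a carboxylic acid or a longer chain such as butyl would do there. Also open is how each of the two chloro groups separately contributes, since the cores shown differ in more than one place.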